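The source may report more compounds than this note shows. Statements on the series, on what has been measured and on what is new or still open speak of the compounds shown alone.

Measured so far:
- compound 1, `COc1ccc(-c2nc3ccccc3s2)cc1OC`: 52700 nM
- compound 2, `COc1ccc(-c2nc3cc(F)ccc3s2)cc1`: 490 nM
- compound 3, `COc1ccc(-c2nc3cc(F)ccc3s2)cc1Cl`: 760 nM

All three were run in a functional assay on MCF7 cells (Homo sapiens) for inhibition; a lower number here means a stronger inhibitor, a higher number a weaker inhibitor. Compound 1 gives the highest number of the set; compound 2 and compound 3 lie far lower. How the core of compound 1 differs from that of compound 2 is not broken down here.

Among the compounds with values here, the one counted step within the measured set is a 1.6-fold higher number from compound 2 to compound 3 (0.19 log units; within the scatter), which is the change (chloro in place of hydrogen on an aromatic carbon). The same kind of change, (chloro in place of hydrogen on an aromatic carbon), leads from compound 1 to compound 4, `COc1ccc(-c2nc3cc(Cl)ccc3s2)cc1OC`, which has not yet been measured in this assay. The two changes are not the same: in compound 3 the chloro sits on the six-membered ring ortho to a methoxy group and meta to a large group, whereas in compound 4 it sits on a six-membered ring that is part of a fused system of two rings, meta and para to a fused ring.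

Compound 4 is expected to give 25000 nM in this assay, within the range 6000 nM to 80000 nM. Within the data shown here, the expected step of a 2.1-fold lower number from compound 1 to compound 4 (0.32 log units; beyond the scatter) rests on the only measured chloro step, which for compound 3 relative to compound 2 stayed within the scatter, and on the fact that no measured pair shows a chloro placed on the fused ring; the estimate therefore keeps compound 4 near compound 1, with a wide range.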

Compound 4, half-maximal inhibitory concentration: 27900 nM
Estimate against measurement, compound 4: 1.1-fold (0.05 log units) below; measured number inside the range.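

In this assay, chloro in place of hydrogen on an aromatic carbon gives a 1.9-fold lower number from compound 1 to compound 4 (0.28 log units; within the scatter), and although each step on its own stays within the scatter, the steps on the two cores do not agree: the same change on two cores in this assay, a 1.6-fold higher number (0.19 log units; within the scatter) from compound 2 to compound 3 and a 1.9-fold lower number (0.28 log units; within the scatter) from compound 1 to compound 4, 2.9-fold (0.47 log units) apart, beyond the scatter of two such steps
The step seen on one core therefore cannot be carried unchanged to the other, although on neither core does the chloro change move the number beyond the scatter. This does not show that the core alone sets the size of the step, since the chloro of compound 4 sits on the fused system of two rings and that of compound 3 does not, so core and place change together across the two steps.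

The compounds shown leave open which single difference separates the high numbers of compound 1 and compound 4 from the far lower numbers of compound 2 and compound 3, as no pair here joins the two groups by a change in one place; fluoro in place of the chloro of compound 4 would give one link of that kind. Also open, as far as these compounds go, is how other groups on that same aromatic carbon, such as bromo, methyl, an amine or a carboxylic acid, would compare with chloro on the core of compound 1.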